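Moving the methoxy group around the benzamide ring

The source may hold more compounds than are shown below. What is called first, only, known or untested is meant among the compounds shown, and "the series" means these compounds.

Compounds measured in a functional assay on the whole organism (strain A/J) for inhibition, with Mus musculus as the target, with stated times of 1 h and 18 h, at a dose of 100 umol/kg by the oral route; a higher number here means more inhibition at the dose given (going by the name of the read-out), a lower number less inhibition:
- compound 1, `COc1ccc(/C=N/N(C)C(=O)c2ccccc2OC)cc1OC`: compound 1 gives 59%
- compound 2, `COc1cccc(C(=O)N(C)/N=C/c2ccc(OC)c(OC)c2)c1`: compound 2 gives 69%
- compound 3, `COc1ccc(/C=N/N(C)c2ncnc3ccccc23)cc1OC`: compound 3 gives 66%

Compound 2 holds the highest of the three numbers, but its nearest neighbour compound 3 sits within the scatter, and so does compound 1; no order among the three can be claimed. Among the compounds with values here, the one step within this set that involves compound 2 is a number 10 percentage points higher from compound 1 to compound 2 (within the scatter), a shift of the methoxy group around the ring attached to the carbonyl carbon that changed nothing beyond the scatter.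

Compound 4, `COc1ccc(C(=O)N(C)/N=C/c2ccc(OC)c(OC)c2)cc1`, is reached from compound 2 by a change of the same kind: 4-methoxyphenyl in place of 3-methoxyphenyl on a carbonyl carbon. Within the data shown here, only the step from compound 1 to compound 2 bears on it, and that step was within the scatter. Compound 4 is therefore expected to show no step beyond the scatter, a number 4 percentage points lower from compound 2 to compound 4 (within the scatter), and its inhibition in this assay is estimated at 65%, with a range from 48% to 80%. Whether the measurement will confirm this remains to be seen.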

Compound 4, a percentage reported as inhibition, in the whole organism at one dose (the size of the read-out at that dose, not a potency): 62%
The estimate for compound 4 lay 3 percentage points above the measured number; measured number inside the range.
By their numbers in this assay, from the lowest: compounds 1, 4, 3 and 2 (each within the scatter of the next).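

In this assay, the 4-methoxyphenyl group now stands on the carbonyl carbon alongside the 2-methoxyphenyl and 3-methoxyphenyl groups, and the two new comparisons give a number 7 percentage points lower from compound 2 to compound 4 (within the scatter) and a number 3 percentage points higher from compound 1 to compound 4 (within the scatter). Together with the earlier step between the 2-methoxyphenyl and 3-methoxyphenyl compounds, this completes the set of three placements of the methoxy group on this ring, and no exchange among them moves the read-out beyond the scatter, so in these three compounds the placement of the methoxy group does not separate one from another. No measurement is available here that would account for this result.

The compounds shown leave open whether anything other than a methoxy group at this place, such as a hydroxy group, a dimethylamino group or a carboxylic acid, would move the read-out beyond the scatter, since all three compounds carry the same group in its different placements. Each compound is also described by a single number at one dose, so these values do not settle whether the three would still fall within the scatter of one another at other doses.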